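Bis(trifluoromethyl) analogue of compound 2 in the mitochondrial assay

This account rests on a few compounds, and the source may have more. Where it says the series, first, only, none or still open, it means among the compounds named here.

Measured so far:
compound 1 `Oc1nc2nonc2nc1Nc1ccc(OCC2CC2)c(C(F)(F)F)c1` — 1800 nM
compound 2 `Oc1nc2nonc2nc1Nc1cccc(C(F)(F)F)c1` — 13300 nM

In an assay on mitochondria from L6 cells (Rattus norvegicus) for activation, with a stated time of 90 min (a higher number here means that more compound is needed for the effect, a lower number that less compound is needed), compound 2 stands highest of the two numbers; the nearest is compound 1, and the step of a 7.4-fold higher number from compound 1 to compound 2 (0.87 log units; beyond the scatter) takes the series from compound 1 to compound 2 through loss of the cyclopropylmethoxy group on an aromatic carbon.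

Compound 3 `Oc1nc2nonc2nc1Nc1cc(C(F)(F)F)cc(C(F)(F)F)c1` differs from compound 2 by trifluoromethyl in place of hydrogen on an aromatic carbon: the new group sits on an aromatic carbon of a six-membered aromatic ring of carbon only, meta to a trifluoromethyl group. Among the measured compounds shown here, no measured step covers a change of this kind at this place; the single step in hand concerns a different group elsewhere on the same ring, so it gives only indirect guidance. The working expectation is therefore a step of no more than modest size in this assay, with direction uncertain, as expressed by a 1.7-fold lower number from compound 2 to compound 3 (0.22 log units; within the scatter). Compound 3 is thus expected at about 8000 nM, within 2500 nM to 25000 nM.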

Compound 3, half-maximal effective concentration: 4500 nM
Compound 3: the middle estimate sits 1.8-fold (0.25 log units) above what was measured; the range from low to high includes it.
By their numbers in this assay, from the lowest: compound 1; then compound 3; then compound 2.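

In this assay, trifluoromethyl in place of hydrogen at this ring carbon, meta to a trifluoromethyl group, gives a 3.0-fold lower number from compound 2 to compound 3 (0.47 log units; beyond the scatter). Among the compounds shown here, the earlier step, a 7.4-fold higher number from compound 1 to compound 2 (0.87 log units; beyond the scatter), spoke only to the cyclopropylmethoxy place, so this is the first reading at a second place on the ring, and a substituent there also goes with a lower number than hydrogen. Within the compounds shown, compound 2 stands highest against a substituent at either place, and no available evidence explains the step.

Open, as far as these compounds go, is whether this place is specific to trifluoromethyl or also accepts another group, such as a nitrile, a methoxy group or a chlorine atom. Also open, from the compounds shown here alone, is how a trifluoromethyl group here would combine with cyclopropylmethoxy on the same ring.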